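Swapping pyridin-3-yl for 1-hydroxyethyl on a triple-bonded carbon

The source may report more compounds than this note shows. Statements on the series, on what has been measured and on what is new or still open speak of the compounds shown alone.

In an ADME assay on HepG2 cells (Homo sapiens) for cytotoxicity, read by MTT assay, with a stated time of 72 h (a higher number here means that more compound is tolerated, a lower number that less compound is tolerated), compound 3 (`O=[N+]([O-])c1c(CS(=O)(=O)c2ccccc2)nc2c(C#Cc3cccnc3)cc(Cl)cn12`) gives > 3900 nM as a limit, not a number. Compound 1 (`O=[N+]([O-])c1c(CS(=O)(=O)c2ccccc2)nc2c(C#Cc3cccc(F)c3)cc(Cl)cn12`) gives > 3900 nM as a limit too. Compound 2 (`O=[N+]([O-])c1c(CS(=O)(=O)c2ccccc2)nc2c(C#Cc3ccccc3F)cc(Cl)cn12`) gives > 3900 nM as a limit as well. Compound 4 (`CC(O)C#Cc1cc(Cl)cn2c([N+](=O)[O-])c(CS(=O)(=O)c3ccccc3)nc12`) carries 1-hydroxyethyl in place of pyridin-3-yl on a triple-bonded carbon. The nearest measured changes swap one ring on that carbon for another, and they offer no size to carry over: a step that the two limits leave unreadable from compound 1 to compound 3 and a step that the two limits leave unreadable from compound 2 to compound 3 and also a step that the two limits leave unreadable from compound 1 to compound 2 tell only of limits. A small move toward more compound tolerated is expected, with a step that the limit leaves unreadable from compound 3 to compound 4 as the estimate. Compound 4 is estimated at 8000 nM with a range from 3000 nM to 30000 nM in this expectation.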

Compound 4, half-maximal cytotoxic concentration: 44200 nM
Beside the measured number, compound 4's estimate is 5.5-fold (0.74 log units) below it; measured number outside the range, above it.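

No step from compound 1, compound 2 or compound 3 to compound 4 can be read, as those three compounds give only a limit: the limit of > 3900 nM in this assay, at which 3 of the 4 values shown sit.

Going by these compounds, how much more compound is tolerated with 1-hydroxyethyl than with each ring on the triple-bonded carbon stays open.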